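A few compounds are considered here, and "the series" means these few. Any claim that something is new, unique, unknown or untested is made for them only; others in the source may bear on it.

Compound 3 `Cc1cc(C)c(CN2CCc3c(Cl)cc([C@@H](CO)[C@@H]4CCCO4)c(Cl)c3C2=O)c(=O)[nH]1` belongs to a small set of compounds built on one shared core. In an assay for inhibition of histone-lysine N-methyltransferase EZH2 variant Y641N (Homo sapiens), read by scintillation counting, with a stated time of 60 min, in the presence of a further agent that is not named here (a lower number here means a stronger inhibitor, a higher number a weaker inhibitor), compound 3 gives 135 nM, the highest of the two single numbers recorded here. Compound 1 `Cc1cc(C)c(CN2CCc3c(Cl)cc([C@H](CO)[C@H]4CCCO4)c(Cl)c3C2=O)c(=O)[nH]1` gives 8 nM in this assay, while compound 2 `Cc1cc(C)c(CN2CCc3c(Cl)cc(C(CO)c4ccon4)c(Cl)c3C2=O)c(=O)[nH]1` gives 360 nM; 24 nM (2 entries), two entries that do not settle on a single number (the several entries of compound 2 in this assay, 360 nM; 24 nM (2 entries)). Among the measured compounds shown here, the one measured step between single numbers is a 17-fold higher number from compound 1 to compound 3 (1.23 log units; beyond the scatter), a large change that arises because of the fact that compounds 1 and 3 differ only in the configuration as drawn, the two being mirror images of each other. Compound 4 `Cc1cc(C)c(CN2CCc3c(Cl)cc([C@@H](CO)[C@H]4CCCO4)c(Cl)c3C2=O)c(=O)[nH]1` differs from compound 3 in this way: the two compounds have the same atoms and bonds and differ only in configuration as drawn: 1 of 2 stereo elements differ; a stereocentre at a saturated ring carbon is drawn S in compound 3 and R in compound 4. For the measured compounds named here, no measured step inverts only the ring centre, so the direction of this change is uncertain; the mirror-image step shows that configuration at these centres can move this assay strongly, and compound 4 sits between the two measured forms in configuration. Compound 4 is expected to show a 2.7-fold lower number from compound 3 to compound 4 (0.43 log units; beyond the scatter). The estimate for compound 4 is 50 nM, with a range from 10 nM to 300 nM.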

Compound 4, inhibition constant: 110 nM
Compound 4: the middle estimate sits 2.2-fold (0.34 log units) below what was measured; the range from low to high includes it.
By their numbers in this assay, from the lowest: compound 1; then compounds 4 and 3 (each within the scatter of the next).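

Compound 4 pulls apart the two centres that changed together in the mirror-image pair. In this assay, inverting only the saturated ring carbon gives a 1.2-fold lower number from compound 3 to compound 4 (0.09 log units; within the scatter), whereas inverting only the saturated chain carbon gives a 14-fold higher number from compound 1 to compound 4 (1.14 log units; beyond the scatter). Among these three compounds, the large change therefore follows the chain centre, and with the ring centre drawn R it comes from configuration alone: the fact that compounds 1 and 4 differ only in the configuration as drawn

From the compounds shown here alone, whether the ring centre matters when the chain centre is drawn R stays open, as the small step above holds only with the chain centre drawn S. Also open is how an amine or a carboxylic acid in place of the hydroxyl group on the chain would behave with the chain centre drawn R or S.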